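This account rests on a few compounds, and the source may have more. Where it says the series, first, only, none or still open, it means among the compounds named here.

In a functional assay on HeLa cells (Homo sapiens) for antiproliferative activity, with a stated time of 24 h (a lower number here means a stronger inhibitor, a higher number a weaker inhibitor), compound 1 `NC(=O)c1c(NC(=O)c2ccccc2Cl)sc2c1CCNC2` gives 45000 nM. Compound 2 `N#Cc1ccccc1CN1CCc2c(sc(NC(=O)c3ccccc3Cl)c2C(N)=O)C1`, which carries 2-cyanobenzyl in place of hydrogen on an amine nitrogen in a ring, stands at > 50000 nM, and this is a limit of the assay, not a number. Among the compounds with values here, the one measured step, an at least 1.1-fold higher number from compound 1 to compound 2 (0.04 log units; that floor lies within the scatter), is therefore only a floor and shows no change beyond the scatter. Compound 3 `NC(=O)c1c(NC(=O)c2ccccc2Cl)sc2c1CCN(Cc1ccccc1F)C2` has fluoro in place of cyano on an aromatic carbon, ortho to a large group, turning 2-cyanobenzyl into 2-fluorobenzyl (fluoro in place of cyano on an aromatic carbon). Within the data shown here, no measured step covers this exchange directly, so the only guide is the small step at this same nitrogen, and no step beyond the scatter is expected in this assay. Compound 3 is expected at about 45000 nM, with an estimated range from 12000 nM to 70000 nM. The expected change is an at least 1.1-fold lower number from compound 2 to compound 3 (0.04 log units; that floor lies within the scatter).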

Compound 3, half-maximal inhibitory concentration: > 50000 nM
Compound 3 was reported as a limit (the forecaster's own chance of this, stated with the estimate: 55%); middle value at least 1.1-fold (0.04 log units) away from the limit.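

In this assay, compound 3 is reported only as a limit, so a second substituted benzyl group on this ring nitrogen, now with fluoro where compound 2 has cyano, also gives no measured number. Putting 2-fluorobenzyl in place of hydrogen on the amine nitrogen gives an at least 1.1-fold higher number from compound 1 to compound 3 (0.04 log units; that floor lies within the scatter), so this change, like the earlier one with 2-cyanobenzyl, shows nothing beyond the scatter. The step between compound 2 and compound 3 cannot be read because both values are limits: the limit of > 50000 nM in this assay, at which 2 of the 3 values shown sit.

The compounds shown therefore leave open whether cyano and fluoro differ at all on this aromatic carbon. They also leave open whether a methoxy group on that same carbon, a carboxylic acid on the benzyl ring, or a simple methyl on the ring nitrogen would give a measurable value.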